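Swapping Octyloxy for Butylsulfanyl: Expected Cytotoxicity of Compound 4

The compounds below may be only part of what the source reports. "The series", "measured", "known", "first", "only" and "open" are said of these compounds alone.

Measured compounds:
compound 1 `Nc1nc(OCC(F)(F)F)c2ncn(/C=C3/CC3(CO)CO)c2n1`: > 20000 nM
compound 2 `CCCCCCCCOc1nc(N)nc2c1ncn2/C=C1/CC1(CO)CO`: > 20000 nM
compound 3 `Nc1nc(N2CCCC2)c2ncn(/C=C3/CC3(CO)CO)c2n1`: > 24000 nM

All three were tested in an ADME assay on Akata cells (Homo sapiens) for cytotoxicity, with a stated time of 7 days; a lower number here means that less compound is tolerated, a higher number that more compound is tolerated. For compound 1 the value is a limit of the assay, > 20000 nM. For compound 2 the value is likewise a limit, > 20000 nM. For compound 3 the value is a limit as well, > 24000 nM. Compound 2 thus stands at a limit, and the two other values shown are limits too: the limit of > 20000 nM in this assay, at which 2 of the 3 values shown sit, holds compound 1 and compound 2, while the limit of > 24000 nM in this assay, at which 1 of the 3 values shown sits, holds compound 3. The steps between measured pairs are accordingly not readable: a step that the two limits leave unreadable from compound 1 to compound 2, a step that the two limits leave unreadable from compound 1 to compound 3, a step that the two limits leave unreadable from compound 2 to compound 3.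

Compound 4 `CCCCSc1nc(N)nc2c1ncn2/C=C1/CC1(CO)CO` has not yet been measured. It differs from compound 2 in one place: butylsulfanyl in place of octyloxy on an aromatic carbon. Among the measured compounds shown here, none of the measured steps gives a readable size, so no size can be read for this change either. With every measured value sitting at a limit, compound 4 is expected to stay at or beyond the limit as well, with no step beyond the scatter. The step from compound 2 is expected to be a step that the limit leaves unreadable from compound 2 to compound 4. Compound 4 is estimated at 25000 nM, in a range from 10000 nM to 60000 nM.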

Compound 4, half-maximal cytotoxic concentration: > 20000 nM
Compound 4: a limit, no number (the forecaster's own chance of this, stated with the estimate: 80%); the middle value lies beyond the limit too.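

In this assay compound 4 gives > 20000 nM, which is a limit. All four values are limits, so the steps to compound 4 from compound 1, compound 2 and compound 3 cannot be read. The compounds shown leave open the half-maximal cytotoxic concentration of each compound, and whether exchanging the groups on this aromatic carbon changes it at all.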